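The source may hold more compounds than are shown below. What is called first, only, known or untested is meant among the compounds shown, and "the series" means these compounds.

In a functional assay on HeLa cells (Homo sapiens) for inhibition (a lower number here means a stronger inhibitor, a higher number a weaker inhibitor), compound 1 `Oc1ccccc1-c1cc(-c2cccc(C(F)(F)F)c2)cc(-c2ccccc2O)n1` gives > 50000 nM, which is a limit of the assay rather than a number. Compound 2 `Oc1ccccc1-c1cc(-c2ccc(C(F)(F)F)cc2)cc(-c2ccccc2O)n1` gives > 50000 nM in this assay, again only a limit. Compound 3 `Oc1ccc(-c2cc(-c3cccc(C(F)(F)F)c3)cc(-c3ccccc3O)n2)cc1` gives > 50000 nM in this assay, also a limit. The change from compound 1 to compound 2 is 4-(trifluoromethyl)phenyl in place of 3-(trifluoromethyl)phenyl on an aromatic carbon, and its step is a step that the two limits leave unreadable from compound 1 to compound 2. Compound 4 `Oc1ccc(-c2cc(-c3ccc(C(F)(F)F)cc3)cc(-c3ccccc3O)n2)cc1` arises from compound 3 by 4-(trifluoromethyl)phenyl in place of 3-(trifluoromethyl)phenyl on an aromatic carbon. The two cores differ by 4-hydroxyphenyl in place of 2-hydroxyphenyl on an aromatic carbon: around the place, the change in compound 1 is made meta to two 2-hydroxyphenyl groups, while in compound 3 it is made meta to a 2-hydroxyphenyl group and meta to a 4-hydroxyphenyl group, so this is the same kind of change, not the same. Since every value shown sits at the limit of > 50000 nM in this assay, at which 3 of the 3 values shown sit, the step from compound 3 to compound 4 is expected to be a step that the limit leaves unreadable from compound 3 to compound 4. Compound 4 is estimated to give about 80000 nM in this assay, most likely again only a limit.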

Compound 4, half-maximal inhibitory concentration: > 50000 nM
Compound 4: no number, only a limit; the forecaster's own chance of this, stated with the estimate: 90%; the middle value lies beyond the limit too.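

In this assay compound 4 gives > 50000 nM, again only a limit, so the steps to it from compound 2 and compound 3 cannot be read. The compounds shown leave open how either change affects inhibition.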